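Replacing the acid on the tail phenyl of an alpha-ketooxazole

The source may report more compounds than this note shows. Statements on the series, on what has been measured and on what is new or still open speak of the compounds shown alone.

Compound 1 `O=C(O)c1cccc(CCCCCCC(=O)c2ncc(-c3ccccn3)o2)c1`: > 600 nM
Compound 2 `CS(=O)(=O)c1cccc(CCCCCCC(=O)c2ncc(-c3ccccn3)o2)c1`: 1.3 nM

In an assay for inhibition of Fatty-acid amide hydrolase 1 (Rattus norvegicus) (a higher number here means a weaker inhibitor, a lower number a stronger inhibitor), compound 1 reaches only a limit, (the limit of > 600 nM in this assay, at which 1 of the 2 values shown sits). Compound 2 gives 1.3 nM, and the step of an at least 460-fold lower number from compound 1 to compound 2 (2.66 log units; beyond the scatter) shows how much the carboxy group costs. Compound 3 `CSc1ccccc1CCCCCCC(=O)c1ncc(-c2ccccn2)o1` carries the change (2-(methylsulfanyl)phenyl in place of 3-carboxyphenyl on a saturated chain carbon, six bonds along the chain from a carbonyl carbon); like compound 2, it has no hydrogen-bond donor and no net charge where compound 1 has a carboxy. That step is the only one that bears on it, and a gain of similar size, in the same direction, is expected: an at least 120-fold lower number from compound 1 to compound 3 (2.07 log units; beyond the scatter). Compound 3 is therefore estimated at 5 nM, within 1 nM to 40 nM.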

Compound 3, inhibition constant: 3.3 nM
Compound 3: the middle estimate sits 1.5-fold (0.18 log units) above what was measured, and the stated range covers the measured number.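

In this assay, 2-(methylsulfanyl)phenyl in place of 3-carboxyphenyl gives an at least 180-fold lower number from compound 1 to compound 3 (2.25 log units; beyond the scatter). The large gain on leaving the carboxylic acid therefore does not depend on the methylsulfonyl group of compound 2, since a differently named and differently substituted phenyl also delivers it. Compound 1 reaches only a limit, so the full size of this step stays unknown: the limit of > 600 nM in this assay, at which 1 of the 3 values shown sits.

The change replaces the whole substituted phenyl at once, so the loss of the carboxy and the entry of methylsulfanyl cannot be separated. Going by these compounds, how an unsubstituted phenyl, a 3-(methylsulfanyl)phenyl or an amine-bearing phenyl would compare remains open.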